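This account rests on a few compounds, and the source may have more. Where it says the series, first, only, none or still open, it means among the compounds named here.

Compound 1 `COc1cccc(N2C(=O)COc3ccc(-c4cnc(Cl)c(NS(=O)(=O)c5ccc(F)cc5)c4)cc32)c1`: > 40000 nM
Compound 2 `O=C1COc2ccc(-c3cccc(NS(=O)(=O)c4ccc(F)cc4)c3)cc2N1c1ccc(Cl)cc1`: 23900 nM

Within the data shown here, in a functional assay on HCT-116 cells (Homo sapiens) for antiproliferative activity, read by MTT assay, with a stated time of 72 h (on this read-out higher numbers stand for weaker inhibition and lower numbers for stronger inhibition), compound 2 gives 23900 nM, the only exact number so far. For compound 1 the entry > 40000 nM is a limit of the assay, not a number.

Compound 3 `COc1ccc(N2C(=O)COc3ccc(-c4cccc(NS(=O)(=O)c5ccc(F)cc5)c4)cc32)cc1` has methoxy in place of chloro on an aromatic carbon, para to a large group: methoxy in place of chloro on an aromatic carbon. Among the measured compounds shown here, no measured pair yet shows the effect of this change, so no shift beyond the scatter is expected in this assay. The expected step of a 1.2-fold higher number from compound 2 to compound 3 (0.07 log units; within the scatter) is small. For compound 3 the estimated value is 28000 nM, with an expected range of 12000 nM to 40000 nM.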

Compound 3, half-maximal inhibitory concentration: 28300 nM
Compound 3: the middle estimate sits 1.0-fold (0.00 log units) below what was measured; the measured number falls inside the stated range.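

On this aromatic carbon, para to a large group, methoxy in place of chloro gives a 1.2-fold higher number from compound 2 to compound 3 (0.07 log units; within the scatter) in this assay. Among these compounds, this is the first pair differing in one place, and it shows that the change from 4-chlorophenyl to 4-methoxyphenyl does not move the read-out beyond the usual scatter. The assay also has a ceiling close to these values: the limit of > 40000 nM in this assay, at which 1 of the 3 values shown sits.

On these data alone, whether an amine or a carboxylic acid at this position would shift the number remains open. So does whether any group here could bring a clearly lower number.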